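This account rests on a few compounds, and the source may have more. Where it says the series, first, only, none or still open, it means among the compounds named here.

Of the compounds shown here, three from one series have been tested, and a fourth awaits its number. Compound 1 `Cc1ccc(/C=C2\CN(C)C[C@@]3(C2=O)[C@@H](c2ccc(C)cc2)CN(C)[C@@]32C(=O)Nc3ccccc32)cc1` has, in a functional assay on the whole organism (strain Wister albino) for inhibition, with Rattus norvegicus as the target, read by paw edema, with stated times of 1 h and 4 h, at a dose of 50 mg/kg by the intraperitoneal route (on this read-out higher numbers stand for more inhibition at the one dose given (going by the name of the read-out) and lower numbers for less inhibition), a value of 50.7%. Compound 2 `Cc1ccc(/C=C2\CN(C)C[C@@]3(C2=O)[C@@H](c2ccc(C)cc2)CN(C)[C@@]32C(=O)N(C)c3ccccc32)cc1` differs from it by a single change, described as methyl in place of hydrogen on an amide-type nitrogen in a ring. In this assay compound 2 gives 68.8%, so the change brought a number 18.1 percentage points higher from compound 1 to compound 2 (beyond the scatter).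

Compound 3 `CN1C/C(=C\c2ccc(-c3cccs3)cc2)C(=O)[C@]2(C1)[C@@H](c1ccc(-c3cccs3)cc1)CN(C)[C@@]21C(=O)Nc2ccccc21` is built on a different core; how its core differs from that of compound 1 is not broken down here. In this assay compound 3 gives 71.4%. This number and that of compound 2 lie within the usual scatter of each other, so no order between them can be claimed, while compound 3 stands clearly above compound 1.

Compound 4 `CN1C/C(=C\c2ccc(-c3cccs3)cc2)C(=O)[C@]2(C1)[C@@H](c1ccc(-c3cccs3)cc1)CN(C)[C@@]21C(=O)N(C)c2ccccc21` is the not yet measured member. Going by the values given here, it differs from compound 3 by methyl in place of hydrogen on an amide-type nitrogen in a ring, which is the same change, at the same kind of place, as the one that turned compound 1 into compound 2. That change was seen only once so far, and compound 3 already starts from a high number, leaving less room for the number to rise. The step expected in this assay is therefore a number 8.6 percentage points higher from compound 3 to compound 4 (within the scatter), smaller than the one seen earlier, because the earlier step of a number 18.1 percentage points higher from compound 1 to compound 2 (beyond the scatter) came from a lower starting point. On this basis compound 4 is estimated to reach about 80% in this assay, with a likely range from 68% to 92%.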

Compound 4, a percentage reported as inhibition, in the whole organism at one dose (the size of the read-out at that dose, not a potency): 69.8%
Estimate against measurement, compound 4: 10.2 percentage points above; the range from low to high includes it.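

In this assay, the same swap of the amide hydrogen for methyl, made on the second core, gave a number 1.6 percentage points lower from compound 3 to compound 4 (within the scatter), so on this core the added methyl leaves no measurable mark on the read-out. The change therefore did not carry over with the same effect, and the two cores give clearly different results for it: the same change on two cores in this assay, a number 18.1 percentage points higher (beyond the scatter) from compound 1 to compound 2 and a number 1.6 percentage points lower (within the scatter) from compound 3 to compound 4, 19.7 percentage points apart, beyond the scatter of two such steps. Going by these compounds alone, this shows that a gain seen on one core of this series cannot simply be assumed on another, but with only two pairs of compounds, one dose and one read-out, it gives no general rule and does not show which feature of the two cores separates the outcomes.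

The compounds shown leave open how the amide nitrogen would respond on either core to a group other than methyl, such as ethyl, a longer chain or a chain ending in an amine or a carboxylic acid. They also leave open whether the contrast between the two cores would hold at other doses, or on a third core carrying the same swap of hydrogen for methyl.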